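The source may report more compounds than this note shows. Statements on the series, on what has been measured and on what is new or still open speak of the compounds shown alone.

Working notes on the series. The shared core runs through all three measured compounds: compound 1 `O=C(CCSC(=S)NCc1cccnc1)NCc1ccccc1` carries it on an open amide, while compound 2 `FC(F)(F)c1ccc(-c2nnc(CCSC(=S)NCc3cccnc3)o2)cc1` and compound 3 `S=C(NCc1cccnc1)SCCc1nnc(-c2ccc(Cl)cc2)o1` carry it on an aryl-substituted five-membered aromatic ring. In a functional assay on MDA-MB-468 cells (Homo sapiens) for cytotoxicity, read by resazurin assay, with a stated time of 72 h (on this read-out higher numbers stand for weaker inhibition and lower numbers for stronger inhibition), compound 1 reaches only the assay limit, > 100000 nM; it is a limit, not a number, as the limit of > 100000 nM in this assay, at which 1 of the 3 values shown sits, records. In this assay compound 2 gives 5490 nM, and compound 3 gives 1980 nM. Within the data shown here, compound 3 therefore stands at the lowest of the two numbers, separated from compound 2 by the single measured step, a 2.8-fold lower number from compound 2 to compound 3 (0.44 log units; beyond the scatter), a modest gain beyond the scatter.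

Compound 4 `Cc1cc(-c2nnc(CCSC(=S)NCc3cccnc3)o2)no1` is not yet measured. It differs from compound 3 by 5-methyl-1,2-oxazol-3-yl in place of 4-chlorophenyl on an aromatic carbon. Among the measured compounds shown here, the one measured step, chloro in place of trifluoromethyl on the same aromatic carbon, keeps the six-membered ring of carbon only and shifts the number only modestly; the ring swap in compound 4 is a change of another kind and no measured step covers it, so its direction rests on the series pattern alone. Given that compound 3 sits at 1980 nM and compound 2 at 5490 nM, compound 4 is expected to land weaker than compound 3, with the step of a 2.5-fold higher number from compound 3 to compound 4 (0.40 log units; beyond the scatter) expected to lie near the edge of the scatter. The estimate for compound 4 in this assay is 5000 nM, with a range from 1500 nM to 20000 nM.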

Compound 4, half-maximal inhibitory concentration: 6140 nM
Compound 4: the middle estimate sits 1.2-fold (0.09 log units) below what was measured; low and high end bracket the measured number.
By their numbers in this assay, from the lowest: compound 3; then compounds 2 and 4 (each within the scatter of the next). At a limit, above all of these: compound 1.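

In this assay this position, the aromatic carbon of the five-membered aromatic ring with 2 nitrogen and 1 oxygen, still gives a measurable number when the six-membered aromatic ring of carbon only gives way to a five-membered aromatic ring with 2 hetero atoms, and the cost is modest: a 3.1-fold higher number from compound 3 to compound 4 (0.49 log units; beyond the scatter) is the whole step. Among these compounds, compound 4 and compound 2 stand within the scatter of each other, so 5-methyl-1,2-oxazol-3-yl and the trifluoromethyl-bearing aryl group cannot be told apart here, and 4-chlorophenyl in compound 3 remains the only group at this carbon whose number stands apart from both. Nothing among the data shown accounts for the size or direction of this step.

Going by these compounds, it remains open whether the lower number of compound 3 follows from the chloro group or from the ring that carries it, which a plain phenyl or a pyridine ring at this carbon would help to separate. Also open, on these data alone, is how an amine or a carboxylic acid on that ring, or a longer chain in the link to the shared core, would read in this assay.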